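The compounds below may be only part of what the source reports. "The series", "measured", "known", "first", "only" and "open" are said of these compounds alone.

Working notes on a small set built on one shared core, read in an assay on isolated protein for inhibition of long-chain fatty acid transport protein 1 (Mus musculus); on this read-out higher numbers stand for weaker inhibition and lower numbers for stronger inhibition.

Compound 3, `CCn1c(CNc2ccccc2)nnc1SCc1nc2cc(Cl)ccc2o1`, carries the thioether-linked fused bicyclic arm and in this assay gives 2300 nM. Compound 1, `CCn1nnc(-c2ccc(NC(=O)CSc3nnc(CNc4ccccc4)n3CC)cc2)n1`, carries an amide arm ending in a tetrazolylphenyl group; its result in this assay is a limit, > 10000 nM, and (the limit of > 10000 nM in this assay, at which 1 of the 3 values shown sits). Compound 2, `CCn1c(CNc2ccccc2)nnc1SCC(=O)Nc1ccc(C(C)=O)cc1`, carries the same amide arm ending in a 4-acetylphenyl group, and for compound 2 this assay records "not determined" (no result reported), so compound 2 stands without a number among the three.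

Compound 4, `CCn1c(CNc2ccccc2)nnc1SCC(=O)Nc1ccccc1`, is the plain phenyl amide. It differs from compound 2 by hydrogen in place of acetyl on an aromatic carbon. No measured step between any two of these compounds is available, and compound 2 itself has no number, so the size and direction of the change from compound 2 to compound 4 in this assay cannot be read from the data; no step beyond the scatter can be claimed either way.

Within the data shown here, the only anchors are compound 3, which in this assay gives 2300 nM, and compound 1. For compound 1 the result is a limit of the assay. Compound 4 is therefore expected to sit toward the weak end, estimated at 8000 nM with a range from 2000 nM to 40000 nM, with a real chance that only a limit is returned.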

Compound 4, half-maximal inhibitory concentration: > 10000 nM
Compound 4 ended at the assay's limit; the forecaster's own chance of this, stated with the estimate: 45%; middle value at least 1.2-fold (0.09 log units) from the limit.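

Compound 1 and compound 4 both stand at a limit in this assay and no step can be read between them, so the comparison ends here: the limit of > 10000 nM in this assay, at which 2 of the 4 values shown sit.

Still open, on these data alone, are the true strengths of compound 1 and compound 4, and what the change from 4-acetylphenyl to phenyl does, as compound 2 has no number.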